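A few compounds are considered here, and "the series" means these few. Any claim that something is new, unique, unknown or untested is made for them only; others in the source may bear on it.

Of the compounds shown here, three sharing one core have been measured in an assay for binding affinity to adenosine receptor A1 (Bos taurus); on this read-out lower numbers stand for stronger inhibition and higher numbers for weaker inhibition. Compound 1 `CCn1c(=O)c2nc(-c3ccc(S(=O)(=O)O)cc3)[nH]c2n(CC)c1=O` gives 755 nM, the second highest of the three numbers. Compound 3 `COc1cc(OC)cc(-c2nc3c(=O)n(C)c(=O)n(C)c3[nH]2)c1` gives 500 nM, which lies within the scatter of compound 1. Compound 2 `CCn1c(=O)c2nc(-c3cccc(S(=O)(=O)O)c3)[nH]c2n(CC)c1=O` gives 8420 nM, clearly beyond the scatter of compound 1. Going by the values given here, compound 4 `CCn1c(=O)c2nc(-c3ccc(S(=O)(=O)N4CCOCC4)cc3)[nH]c2n(CC)c1=O` differs from compound 1 in one place: morpholin-4-yl in place of hydroxy on a sulfonyl sulfur Since no measured pair shows this change, its size can only be guessed. The step from compound 1 to compound 4 is expected to be modest and towards a lower number, around a 2.5-fold lower number from compound 1 to compound 4 (0.40 log units; beyond the scatter), with much uncertainty. Compound 4 is therefore estimated at 300 nM, within a range from 60 nM to 1500 nM.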

Compound 4, half-maximal inhibitory concentration: 13 nM
Estimate against measurement, compound 4: 23-fold (1.36 log units) above; measured number outside the range, below it.
By their numbers in this assay, from the lowest: compound 4; then compounds 3 and 1 (each within the scatter of the next); then compound 2.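

Putting morpholin-4-yl in place of hydroxy on a sulfonyl sulfur gives a 58-fold lower number from compound 1 to compound 4 (1.76 log units; beyond the scatter) in this assay. Going by these compounds alone, this shows that a change at this one place can move the number by a large amount, which the earlier compounds could not show, as no two of them differ in one place. No measurement available here accounts for the size of this step.

Still open, from the compounds shown here alone, is whether the morpholine ring itself matters, or whether a simple dimethylamino group on the sulfonyl sulfur would do the same. Going by these compounds, the same swap on compound 2 also remains open.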